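Two measured compounds and one estimate of permeability

A few compounds are considered here, and "the series" means these few. Any claim that something is new, unique, unknown or untested is made for them only; others in the source may bear on it.

Compound 1: `Cc1cccc(Cl)c1-c1nc(CN2CCC(C(=O)NCCCN3CCCC(C)C3)CC2)c(C)o1` — 651 10^-6 cm/s
Compound 2: `Cc1cccc(-c2nc(CN3CCC(C(=O)NCCCN4C[C@H](C)C[C@H](C)C4)CC3)c(C)o2)c1` — 279 10^-6 cm/s

Both compounds were run in a physicochemical assay for permeability, using PAMPA; on this read-out higher numbers stand for higher permeability and lower numbers for lower permeability. Compound 2 stands lowest of the two numbers; its nearest neighbour is compound 1, whose number is higher by a margin beyond the scatter. The pair differ in several places, so no single step can be read from them.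

Compound 3 is `COc1ccc(-c2nc(CN3CCC(C(=O)NCCCN4C[C@H](C)C[C@H](C)C4)CC3)c(C)o2)cc1OC`. It differs from compound 2 in one place: 3,4-dimethoxyphenyl in place of 3-methylphenyl on an aromatic carbon. For the measured compounds named here, no measured step of this kind is available. For compound 3 a decrease beyond the scatter is expected, a 1.9-fold lower number from compound 2 to compound 3 (0.27 log units; within the scatter). Compound 3 is therefore estimated at 150 10^-6 cm/s, within 60 10^-6 cm/s to 380 10^-6 cm/s.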

Compound 3, apparent permeability: 81.9 10^-6 cm/s
Beside the measured number, compound 3's estimate is 1.8-fold (0.26 log units) above it; the measured number falls inside the stated range.
By their numbers in this assay, from the lowest: compound 3; then compound 2; then compound 1.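

For the compounds shown here, the step from 3-methylphenyl to 3,4-dimethoxyphenyl on an aromatic carbon of the five-membered aromatic ring is the first single-place comparison in this assay (a 3.4-fold lower number from compound 2 to compound 3 (0.53 log units; beyond the scatter)). It shows that a change at this position alone can move the read-out beyond the scatter, which the earlier pair, differing in several places, could not show. No measurement shown accounts for this step. On these data alone, whether a phenyl with a single methoxy group or an aminophenyl at this position would give a similar step remains open.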